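A few compounds are considered here, and "the series" means these few. Any claim that something is new, unique, unknown or untested is made for them only; others in the source may bear on it.

Three compounds were characterised in an assay on cells for inhibition of protein deacetylase HDAC6 (Homo sapiens), read by fluorescence, with stated times of 15 min and 60 min; a lower number here means a stronger inhibitor, a higher number a weaker inhibitor. Compound 1 `CCCc1cc(-c2ccc(F)cc2)nn1Cc1ccc(C(=O)NO)cc1` gives 107 nM in this assay. Compound 2 `O=C(CCCCCNC(=O)c1cc(-c2ccc(F)cc2)[nH]n1)NO`, in which the hydroxamic acid sits at the end of a saturated chain attached through an amide to the pyrazole core, gives 29 nM. Compound 3 `O=C(NO)c1ccc(Cn2nc(Cc3ccccc3)cc2-c2ccc(F)cc2)cc1` gives 420 nM. Of the three numbers, compound 2 stands lowest, and its gaps to compound 1 and to compound 3 both lie beyond the usual scatter of this assay, so compound 2 is the strongest inhibitor in this set.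

Compound 4 `O=C(CCCNC(=O)c1cc(-c2ccc(F)cc2)[nH]n1)NO` has not yet been measured. It differs from compound 2 in one place: hydroxycarbamoyl in place of 2-(hydroxycarbamoyl)ethyl on a saturated chain carbon, three bonds along the chain from an amide-type nitrogen. The chain between the amide nitrogen and the hydroxamic acid is thus shorter in compound 4 than in compound 2, while the cap and the amide linkage are unchanged.

Going by the values given here, no measured pair in this set shows what such a shortening does in this assay, so the expectation for compound 4 rests on compound 2 alone. Because compound 2 gives 29 nM with the longer chain, the shorter chain of compound 4 is expected to give a weaker inhibitor, with a step of a 10-fold higher number from compound 2 to compound 4 (1.01 log units; beyond the scatter) in this assay. Compound 4 is therefore estimated at 300 nM, within a range from 80 nM to 1200 nM.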

Compound 4, half-maximal inhibitory concentration: 1060 nM
The estimate for compound 4 lay 3.5-fold (0.55 log units) below the measured number; the measured number falls inside the stated range.
By their numbers in this assay, from the lowest: compound 2; then compound 1; then compound 3; then compound 4.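

With compound 4, the set gains its first comparison of two compounds that differ in one place: in this assay, hydroxycarbamoyl in place of 2-(hydroxycarbamoyl)ethyl on a saturated chain carbon, three bonds along the chain from an amide-type nitrogen, gives a 37-fold higher number from compound 2 to compound 4 (1.56 log units; beyond the scatter). The length of the saturated chain at this position therefore has a large effect on the number in this pair, even though the cap, the amide linkage and the terminal hydroxamic acid are all unchanged. No independent measurement shown here bears on why shortening the chain has this effect.

With only two chain lengths in this series, the compounds shown leave open whether the number rises steadily or abruptly as the chain shortens, and whether a chain of intermediate length, or one longer than that of compound 2, would give a lower number still. Also open, as far as these compounds go, is whether a carboxylic acid at the chain end would follow the same trend, and whether the same shortening would have a comparable effect on a cap with an unsubstituted phenyl ring.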